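Hydroxy and bromo groups brought together in compound 3

This account rests on a few compounds, and the source may have more. Where it says the series, first, only, none or still open, it means among the compounds named here.

Going by the values given here, only two compounds have readings so far in an ADME assay on HEK293 cells (Homo sapiens) for cytotoxicity, read by reporter gene assay and resazurin assay, with a stated time of 48 h (on this read-out lower numbers stand for higher toxicity in this test and higher numbers for lower toxicity in this test), at this stage. There compound 1 `O=C(Nc1cccc(Cl)c1)c1ccccc1O` gives 37000 nM and compound 2 `O=C(Nc1cccc(Cl)c1)c1cccc(Br)c1` gives 51000 nM as its reading, two numbers that lie within the usual scatter of each other. Among the compounds with values here, compound 2 therefore cannot be told apart from compound 1, the only other compound measured. Compound 1 carries a hydroxy group on the shared core and compound 2 a bromo group, while compound 3 `O=C(Nc1cccc(Cl)c1)c1cccc(Br)c1O` carries both. The change hydroxy in place of hydrogen on an aromatic carbon leads from compound 2 to compound 3. Within the data shown here, no measured pair shows this change on its own, so the expectation rests on little. The expected change in this assay is modest, toward lower numbers and thus higher toxicity, with a 2.6-fold lower number from compound 2 to compound 3 (0.41 log units; beyond the scatter) as the estimated step. For compound 3 the estimated value is 20000 nM within a range from 6000 nM to 55000 nM in this estimate.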

Compound 3, half-maximal cytotoxic concentration: 32000 nM
The estimate for compound 3 lay 1.6-fold (0.20 log units) below the measured number, and the stated range covers the measured number.
By their numbers in this assay, from the lowest: compounds 3, 1 and 2 (each within the scatter of the next).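

In this assay, the hydroxy group placed on an aromatic carbon, ortho to a bromo group, gives a 1.6-fold lower number from compound 2 to compound 3 (0.20 log units; within the scatter), and the bromo group in place of hydrogen on an aromatic carbon gives a 1.2-fold lower number from compound 1 to compound 3 (0.06 log units; within the scatter). With both steps within the scatter, carrying the two groups together on the shared core gives a reading that cannot be told apart from the reading with either group alone, so neither change registers as a measurable step in this read-out. No independent measurement bears on this result.

The compounds shown leave open whether an amine or a carboxylic acid in place of the hydroxy group would also stay within the scatter of compound 2. They also leave open whether a hydroxy group on this carbon would give a similar step without the bromo group present.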